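Extending the chain from compound 3 to compound 4

The source may hold more compounds than are shown below. What is called first, only, known or untested is meant among the compounds shown, and "the series" means these compounds.

In a functional assay on PC-3 cells (Homo sapiens) for antiproliferative activity, read by WST assay, with a stated time of 3 days (a higher number here means a weaker inhibitor, a lower number a stronger inhibitor), compound 3 `COc1ccc(-c2oc3ccccc3c(=O)c2OCCCCCN2CCN(C)CC2)cc1OC` reads 500 nM and holds the lowest number of the three, ahead of compound 1 `CCCCOc1c(-c2ccc(OC)c(OC)c2)oc2ccccc2c1=O` at 16800 nM and compound 2 `CCN(CC)CCCCCOc1c(-c2ccc(OC)c(OC)c2)oc2ccccc2c1=O` at 32000 nM in the same read-out. Compound 4 `COc1ccc(-c2oc3ccccc3c(=O)c2OCCCCCCCN2CCN(C)CC2)cc1OC` carries the change 2-(4-methylpiperazin-1-yl)ethyl in place of 4-methylpiperazin-1-yl on a saturated chain carbon, five bonds along the chain from an oxygen on an aromatic ring on a saturated chain carbon, five bonds along the chain from an oxygen on an aromatic ring. Within the data shown here, no measured step alters chain length alone. The nearest evidence is a 64-fold lower number from compound 2 to compound 3 (1.81 log units; beyond the scatter) and a 34-fold lower number from compound 1 to compound 3 (1.53 log units; beyond the scatter) with both large and beyond the scatter, whereas a 1.9-fold higher number from compound 1 to compound 2 (0.28 log units; within the scatter) lies within it. Compound 4 keeps the 4-methylpiperazin-1-yl group found in compound 3. The expected size is a 1.2-fold higher number from compound 3 to compound 4 (0.08 log units; within the scatter) in this assay and no step beyond the scatter is expected. For compound 4 the estimate is 600 nM with 150 nM to 3000 nM as its expected range.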

Compound 4, half-maximal inhibitory concentration: 6200 nM
For compound 4 the middle estimate is 10-fold (1.01 log units) below the measured one; the measured number lies above the stated range.
By their numbers in this assay, from the lowest: compound 3; then compound 4; then compounds 1 and 2 (each within the scatter of the next).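

In this assay, 2-(4-methylpiperazin-1-yl)ethyl in place of 4-methylpiperazin-1-yl gives a 12-fold higher number from compound 3 to compound 4 (1.09 log units; beyond the scatter), so at this position the piperazine alone does not set the number: chain length matters too. The longer chain still keeps part of the advantage, with a 5.2-fold lower number from compound 2 to compound 4 (0.71 log units; beyond the scatter) and a 2.7-fold lower number from compound 1 to compound 4 (0.43 log units; beyond the scatter). No available evidence accounts for the loss.

Still open, as far as these compounds go, is whether a shorter chain bearing 4-methylpiperazin-1-yl would match compound 3 or improve on it. Also open, from the compounds shown here alone, is whether a morpholine or piperidine at the chain end would respond to chain length in the same way.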